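Bromo for methyl on the benzyl sulfanyl arm

A few compounds are considered here, and "the series" means these few. Any claim that something is new, unique, unknown or untested is made for them only; others in the source may bear on it.

Three members of the series have been measured. Compound 3 `Cc1ccc(S/C(=C/c2ccc(Oc3ccccc3)cc2)C(=O)c2ccc(Br)cc2)cc1` and compound 2 `O=C(/C(=C\c1ccc(Oc2ccccc2)cc1)Sc1ccc(Br)cc1)c1ccc(Br)cc1` differ in one place, (bromo in place of methyl on an aromatic carbon), and in a functional assay on DU-145 cells (Homo sapiens) for inhibition, read by trypan blue exclusion, with a stated time of 96 h (a higher number here means a weaker inhibitor of growth, a lower number a stronger inhibitor of growth), compound 3 gives 1000 nM while compound 2 gives 50000 nM, a step of a 50-fold higher number from compound 3 to compound 2 (1.70 log units; beyond the scatter). Compound 1 `Cc1ccc(CS/C(=C/c2ccc(F)c([N+](=O)[O-])c2)C(=O)c2ccc(Cl)c([N+](=O)[O-])c2)cc1` gives 1000 nM in this assay; the difference between its core and the core of compound 3 is not broken down here. Compound 4 `O=C(/C(=C\c1ccc(F)c([N+](=O)[O-])c1)SCc1ccc(Br)cc1)c1ccc(Cl)c([N+](=O)[O-])c1` is not yet measured and differs from compound 1 by bromo in place of methyl on an aromatic carbon, the same change as from compound 3 to compound 2, made on a different core. Resting on that single earlier step, a weakening of similar direction, a 20-fold higher number from compound 1 to compound 4 (1.30 log units; beyond the scatter), is expected for compound 4, with wide uncertainty because only one example of this step is available. In this assay compound 4 is estimated at 20000 nM, between 3000 nM and 100000 nM.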

Compound 4, concentration for 50% growth inhibition: > 100000 nM
Compound 4: no number, only a limit (the forecaster's own chance of this, stated with the estimate: 10%); at least 5.0-fold (0.69 log units) between middle value and limit.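

In this assay, bromo in place of methyl weakens growth inhibition on both cores, with an at least 100-fold higher number from compound 1 to compound 4 (2.00 log units; beyond the scatter). Compound 4 gives > 100000 nM, which is a limit of the assay and not a number. The direction of the step therefore carries from the core of compound 3 to the core of compound 1, but two cores make no general rule for the series and the size of the step stays unresolved: the same change on two cores in this assay, a 50-fold higher number (1.70 log units; beyond the scatter) from compound 3 to compound 2 and an at least 100-fold higher number (2.00 log units; beyond the scatter) from compound 1 to compound 4; the limit leaves it open whether they differ

As far as these compounds go, it remains open whether an ethyl, a methoxy or an amine in place of the methyl would keep the strength of the methyl compounds or lose it as bromo does. From the compounds shown here alone, whether the step holds on any further core is also open.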